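A few compounds are considered here, and "the series" means these few. Any claim that something is new, unique, unknown or untested is made for them only; others in the source may bear on it.

Compound 1, whose structure is `CCCCNC(=O)Nc1cc2nc(C3CCCCC3)[nH]c2cc1N(CC)CC`, has been examined in an ADME assay on Vero cells (Chlorocebus sabaeus) for cytotoxicity, read by resazurin assay, with a stated time of 3 days (a higher number here means a weaker inhibitor, a lower number a stronger inhibitor), and there compound 1 gives > 100 ug/mL, which is a limit of the assay rather than a number. A second compound with the same core, compound 2, with the structure `CCCCOC(=O)Nc1cc2nc(C3CCCCC3)[nH]c2cc1N(C)C`, has been run in this assay as well; in this assay compound 2 gives > 100 ug/mL, again a limit and not a number. For the measured compounds named here, what the two results show is summed up by the limit of > 100 ug/mL in this assay, at which 2 of the 2 values shown sit, so compound 1 stands where every value so far stands, at the edge of what the assay reports, and no step between measured compounds can be drawn from it.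

The next compound in line, compound 3, has the structure `CCN(CC)c1cc2[nH]c(C3CCCCC3)nc2cc1NC(=O)c1ccc(F)cc1`. Compared with compound 1 the change is 4-fluorophenyl in place of butylamino on a carbonyl carbon, in words 4-fluorophenyl in place of butylamino on a carbonyl carbon. Nothing measured here tells how such a change acts in this assay. The expected step from compound 1 to compound 3 is an at least 1.1-fold lower number from compound 1 to compound 3 (0.04 log units; that floor lies within the scatter), which is taken to be none beyond the scatter. Compound 3 is therefore estimated at 90 ug/mL, with a range from 40 ug/mL to 200 ug/mL.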

Compound 3, half-maximal inhibitory concentration: > 100 ug/mL
Compound 3 gave a limit, no number; the forecaster's own chance of this, stated with the estimate: 55%; middle value at least 1.1-fold (0.04 log units) away from the limit.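

In this assay compound 3 gives > 100 ug/mL as a limit of the assay and not a number. For the compounds shown here, compound 1 also stands at a limit, so no step from compound 1 to compound 3 can be read: the limit of > 100 ug/mL in this assay, at which 3 of the 3 values shown sit. The compounds shown leave open how far any of them lies from that limit, and whether 4-fluorophenyl in place of butylamino on a carbonyl carbon changes the cytotoxicity at all.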